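Compound 2 to Compound 3: One Amine Exchanged

The source may hold more compounds than are shown below. What is called first, only, known or untested is meant among the compounds shown, and "the series" means these compounds.

Of the compounds shown here, two have so far been measured in a functional assay on MGC-803 cells (Homo sapiens) for cytotoxicity, read by MTT assay, with a stated time of 48 h; a lower number here means a stronger inhibitor, a higher number a weaker inhibitor. Compound 1 `CC1=NN(C(=O)CCl)C(c2cc(Br)ccc2O)C1` gives 13500 nM, and compound 2 `CC(C)(C)NCC(=O)N1N=C(c2cc3ccccc3oc2=O)CC1c1ccccc1` gives 15400 nM; the two numbers sit within the scatter of each other, so neither compound stands apart. Compound 3 `NC(=O)C1CCN(CC(=O)N2N=C(c3cc4ccccc4oc3=O)CC2c2ccccc2)CC1` is not yet measured and differs from compound 2 in one place (4-carbamoylpiperidin-1-yl in place of (tert-butyl)amino on a saturated chain carbon bound to a carbonyl carbon). Among the measured compounds shown here, no measured pair shows this change, so no step beyond the scatter is expected in this assay, in either direction. Compound 3 is therefore estimated at 15000 nM, within 5000 nM to 45000 nM. The step of a 1.0-fold lower number from compound 2 to compound 3 (0.01 log units; within the scatter) is expected to stay inside the scatter.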

Compound 3, half-maximal inhibitory concentration: 21500 nM
Compound 3: the middle estimate sits 1.4-fold (0.16 log units) below what was measured; the measured number falls inside the stated range.
By their numbers in this assay, from the lowest: compounds 1, 2 and 3 (each within the scatter of the next).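

At this position, on a saturated chain carbon bound to a carbonyl carbon, exchanging (tert-butyl)amino for 4-carbamoylpiperidin-1-yl in this assay gives a 1.4-fold higher number from compound 2 to compound 3 (0.14 log units; within the scatter) and so shows that this position accepts a six-membered non-aromatic ring without a step beyond the scatter. Nothing measured here offers an explanation for this result. The compounds shown leave open whether a different group at this position, such as morpholin-4-yl, a primary amine or a carboxylic acid, would move the number beyond the scatter.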